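The source may report more compounds than this note shows. Statements on the series, on what has been measured and on what is new or still open speak of the compounds shown alone.

Compound 2 `O=C1c2ccccc2S(=O)(=O)N1CCCCCCN1CCN(c2ccccc2C(F)(F)F)CC1` is examined in an ADME assay on HEK293 cells for displacement of a labelled ligand from 5-hydroxytryptamine receptor 7 (Homo sapiens), read by radioligand binding, with a stated time of 1 h (a lower number here means a stronger inhibitor, a higher number a weaker inhibitor), where compound 2 gives 195 nM. Going by the values given here, that is the lowest of the two numbers so far, but its nearest neighbour, compound 1 `COc1cccc(N2CCN(CCCCCCN3C(=O)c4ccccc4S3(=O)=O)CC2)c1`, sits within the scatter: compound 1 gives 305 nM. Among the compounds with values here, the only measured step, a 1.6-fold lower number from compound 1 to compound 2 (0.19 log units; within the scatter), changes the group on the same ring nitrogen and stays within the scatter. Compound 3 `O=C1c2ccccc2S(=O)(=O)N1CCCCCCN1CCN(c2cccc(C(F)(F)F)c2)CC1` differs from compound 2 by 3-(trifluoromethyl)phenyl in place of 2-(trifluoromethyl)phenyl on an amine nitrogen in a ring. Within the data shown here, no measured step moves the trifluoromethyl group between the two positions, so the step from compound 1 to compound 2 is the only guide, and it was small. Compound 3 is therefore expected to show no change beyond the scatter in this assay, with the estimated step being a 1.2-fold higher number from compound 2 to compound 3 (0.07 log units; within the scatter). Compound 3 is estimated at 230 nM, within a range from 80 nM to 650 nM.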

Compound 3, inhibition constant: 58 nM
For compound 3 the middle estimate is 4.0-fold (0.60 log units) above the measured one, and the stated range ends above it.
By their numbers in this assay, from the lowest: compound 3; then compounds 2 and 1 (each within the scatter of the next).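

In this assay, the position of the trifluoromethyl group on the phenyl ring matters: 3-(trifluoromethyl)phenyl in place of 2-(trifluoromethyl)phenyl gives a 3.4-fold lower number from compound 2 to compound 3 (0.53 log units; beyond the scatter), although the two groups have the same atoms. Trifluoromethyl in place of methoxy gives a 5.3-fold lower number from compound 1 to compound 3 (0.72 log units; beyond the scatter), with the position on the phenyl ring unchanged. The earlier step from 3-methoxyphenyl to 2-(trifluoromethyl)phenyl changed both the group and its position at once and stayed within the scatter. Nothing given here accounts for either step.

The compounds shown leave open whether a chlorine atom or a nitrile in place of the trifluoromethyl group would give a similar number. They also leave open whether this gain would hold with a shorter chain joining the piperazine-type ring to the shared core.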